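The source may report more compounds than this note shows. Statements on the series, on what has been measured and on what is new or still open speak of the compounds shown alone.

Compound 1 `COc1ccc(NC(=O)C(=O)c2cn(C(C)C)c3ccccc23)cn1` holds the higher of the two numbers recorded so far in a physicochemical assay for solubility, in phosphate buffer, at pH 7.4; on this read-out lower numbers stand for lower solubility and higher numbers for higher solubility: compound 1 gives 20000 nM. Compound 2 `COCCn1cc(C(=O)C(=O)Nc2ccc(OC(C)C)nc2)c2ccccc21` lies nearest to it; in this assay compound 2 gives 10000 nM, and this gap stays within the scatter of repeated measurements, so no order between the two compounds can be read from it. Compound 3 `CCn1cc(C(=O)C(=O)Nc2ccc(OC)nc2)c2ccccc21` has not yet been measured. It differs from compound 1 in one place: hydrogen in place of methyl on a saturated chain carbon bound to an aromatic nitrogen and a saturated chain carbon. Going by the values given here, no step between measured compounds of this kind is available, so the expectation rests on the structural change alone, and it is a small one: the step from compound 1 to compound 3 is expected to be a 1.3-fold higher number from compound 1 to compound 3 (0.10 log units; within the scatter), a shift that would not exceed the usual scatter. Compound 3 is accordingly estimated at 25000 nM, with a range from 10000 nM to 60000 nM.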

Compound 3, solubility: 10000 nM
Compound 3: the middle estimate sits 2.5-fold (0.40 log units) above what was measured; measured number inside the range.
By their numbers in this assay, from the lowest: compounds 2, 3 and 1 (each within the scatter of the next).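

Going by these compounds alone, compound 1 and compound 3 give the first step at this position that can be read on its own: in this assay, isopropyl to ethyl on the aromatic nitrogen gives a 2.0-fold lower number from compound 1 to compound 3 (0.30 log units; within the scatter) and so sets no order between the two compounds. For this one change, hydrogen in place of methyl on a saturated chain carbon, the read-out therefore shows no difference that stands clear of the scatter. No supporting data are available to explain the values at this position.

As far as these compounds go, whether a longer chain, an amine or a carboxylic acid at this position would give a step beyond the scatter remains open. Also open, from the compounds shown here alone, is whether the same change from isopropyl to ethyl would give a similar step on a core carrying a different group.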